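The source may hold more compounds than are shown below. What is called first, only, known or untested is meant among the compounds shown, and "the series" means these compounds.

Of the compounds shown here, two have been measured here. Compound 1 `Cc1ccccc1OCC1=NCCO1` carries a methyl group on its aromatic ring, and in a toxicity assay on the whole organism with Rattus norvegicus as the target, at a dose of 400 mg/kg by the oral route (a lower number here means a weaker effect, a higher number a stronger effect of the compound at the dose given), compound 1 gives 100%. Compound 2 `Brc1ccc(OCC2=NCCO2)cc1` carries a bromo group instead, and in this assay compound 2 gives 100%. On these numbers compound 2 stands level with compound 1, with no change at the digits shown, so the two cannot be ranked against each other.

Compound 3 `O=[N+]([O-])c1ccc(OCC2=NCCO2)cc1` has not yet been measured. It differs from compound 2 in one place: nitro in place of bromo on an aromatic carbon. Since both measured compounds already reach the same high read-out, the step to compound 3 is expected to be none beyond the scatter, which is no change at the digits printed from compound 2 to compound 3 (within the scatter). For compound 3 the expected read-out in this assay is therefore 100%, within a range from 85% to 100%.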

Compound 3, a percentage reported as activity, at one dose (the size of the read-out at that dose, not a potency): 100%
Compound 3: middle estimate and measured number agree at the digits printed; the range from low to high includes it.
By their numbers in this assay, from the lowest: compounds 1, 2 and 3 (each within the scatter of the next).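

In this assay, the exchange of bromo for nitro on the aromatic carbon para to a group of 7 heavy atoms gives no change at the digits printed from compound 2 to compound 3 (within the scatter). This position therefore accepts a group of 3 heavy atoms with 2 hydrogen-bond acceptors in place of a single bromine atom, without any difference in the read-out at this dose. No supporting measurement is available to explain this result.

As far as these compounds go, with only one dose and one shared number, bromo and nitro cannot be ranked against each other, and it remains open whether a lower dose would separate them. From the compounds shown here alone, it is also open whether a group of another kind on the same carbon, such as an amine or a carboxylic acid, would give a different read-out.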